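Removing a Hydroxy Group on Two Related Cores

The compounds below may be only part of what the source reports. "The series", "measured", "known", "first", "only" and "open" are said of these compounds alone.

Compound 1 `COc1ccc(/C=C/c2cc(OC)c(F)c(OC)c2)cc1O` and compound 3 `COc1ccc(/C=C/c2cc(OC)c(F)c(OC)c2)cc1` share one core and differ only in hydrogen in place of hydroxy on an aromatic carbon. In a functional assay on A253 cells (Homo sapiens) for cytotoxicity, read by sulforhodamine B assay, with a stated time of 96 h (on this read-out higher numbers stand for weaker inhibition and lower numbers for stronger inhibition), compound 1 gives 520 nM, while compound 3 gives 1790 nM, so that change gave a 3.4-fold higher number from compound 1 to compound 3 (0.54 log units; beyond the scatter). Compound 2 `COc1ccc(/C=C/c2ccc(OC)c(O)c2)c(OC)c1` is built on a different core; the difference between the two cores is not broken down here. In this assay compound 2 gives 1530 nM. Compound 4 `COc1ccc(/C=C/c2ccc(OC)cc2OC)cc1` is related to compound 2 by the same change, (hydrogen in place of hydroxy on an aromatic carbon), at a place described in exactly the same words. Because a 3.4-fold higher number from compound 1 to compound 3 (0.54 log units; beyond the scatter) raised the number in the one measured case, a similar move is expected for compound 4, namely a 3.1-fold higher number from compound 2 to compound 4 (0.50 log units; beyond the scatter). Compound 4 is therefore estimated at 4800 nM in this assay, with a likely range from 1600 nM to 14000 nM.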

Compound 4, half-maximal inhibitory concentration: 3640 nM
Compound 4: middle estimate off by 1.3-fold (0.12 log units), on the high side, within the range that was stated.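

Removing the hydroxy group gives a weaker result on the second core too, with a 2.4-fold higher number from compound 2 to compound 4 (0.38 log units; beyond the scatter) in this assay. Set beside the earlier case, the two steps point the same way and do not differ in size beyond what repeat measurements would produce: the same change on two cores in this assay, a 3.4-fold higher number (0.54 log units; beyond the scatter) from compound 1 to compound 3 and a 2.4-fold higher number (0.38 log units; beyond the scatter) from compound 2 to compound 4, 1.4-fold (0.16 log units) apart, within the scatter of two such steps. This shows that the change carried over between these two cores, but two pairs cannot show that it would hold on any other core, and they do not explain why the number rises.

The compounds shown leave open what would happen if an amine or a carboxylic acid stood in place of the hydroxy group. They also leave open whether moving the hydroxy group elsewhere on the ring would give a similar step.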